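Chloro enters the shared core of compound 1

A few compounds are considered here, and "the series" means these few. Any claim that something is new, unique, unknown or untested is made for them only; others in the source may bear on it.

Compound 1 `Nc1cc(-n2nnnc2C(=O)Nc2ccc(-c3ccccc3S(N)(=O)=O)cc2)ccc1Cl` is tested in an assay on isolated protein for inhibition of serine protease 1 (Homo sapiens); a higher number here means a weaker inhibitor, a lower number a stronger inhibitor. In this assay compound 1 gives only a limit, > 1600 nM. Compound 2 `COc1ccc(-n2nnnc2C(=O)Nc2ccc(-c3ccccc3S(N)(=O)=O)cc2)cc1` also gives only a limit in this assay, > 1600 nM. Compound 3 `COc1ccc(-n2nnnc2C(=O)Nc2ccc(-c3ccccc3S(N)(=O)=O)cc2)cc1N` likewise gives only a limit in this assay, > 1600 nM. The three steps among them, a step that the two limits leave unreadable from compound 1 to compound 2, a step that the two limits leave unreadable from compound 1 to compound 3 and a step that the two limits leave unreadable from compound 2 to compound 3, therefore carry no readable size, as the limit of > 1600 nM in this assay, at which 3 of the 3 values shown sit, shows. Compound 4 `Nc1cc(-n2nnnc2C(=O)Nc2ccc(-c3ccccc3S(N)(=O)=O)cc2Cl)ccc1Cl` differs from compound 1 by chloro in place of hydrogen on an aromatic carbon. Within the data shown here, none of the measured steps touches this place, and none has a readable size, so they give no direction or size to expect for this step in this assay; the limit is the only anchor. Compound 4 is expected near 3000 nM, within 800 nM to 12000 nM. The estimated step that the limit leaves unreadable from compound 1 to compound 4 is expected to be none beyond the scatter, with a fair chance that this assay again returns only a limit.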

Compound 4, inhibition constant: > 1600 nM
Compound 4: only a limit was reported; the forecaster's own chance of this, stated with the estimate: 70%; the middle value lies beyond the limit too.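

In this assay compound 4 also returns only a limit, > 1600 nM, so no step can be read between compound 1 and compound 4: the limit of > 1600 nM in this assay, at which 4 of the 4 values shown sit.

Going by these compounds, whether chloro in place of hydrogen on this aromatic carbon changes inhibition at all, and in which direction, stays open.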